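Ester shortening in an isatin-derived antiproliferative series

The source may hold more compounds than are shown below. What is called first, only, known or untested is meant among the compounds shown, and "the series" means these compounds.

Measured compounds:
Compound 1 `COc1ccc(-c2ccc3c(c2)C(=O)C(=O)N3C)cc1` in a functional assay on K562 cells (Homo sapiens) for antiproliferative activity, read by MTT assay, with a stated time of 48 h (a higher number here means a weaker inhibitor, a lower number a stronger inhibitor), gives 4980 nM.
Compound 2 `CCN1C(=O)C(=O)c2cc(-c3ccc(OC)cc3)ccc21` in this assay gives 2200 nM.
Compound 3 `CCOC(=O)/C=C1\C(=O)N(Cc2ccc(OC)cc2)c2ccc(-c3ccc(OC)cc3)cc21` in this assay gives 1240 nM.

Compound 3 has the lowest number of the three in this assay; its values and those of compound 2 lie within the usual scatter of each other, while compound 1 stands further off. Compound 4 `COC(=O)/C=C1\C(=O)N(Cc2ccc(OC)cc2)c2ccc(-c3ccc(OC)cc3)cc21` has not yet been measured in this assay. It differs from compound 3 by hydrogen in place of methyl on a saturated chain carbon bound to an oxygen next to a carbonyl group.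

A change of the same kind is seen between two measured compounds: compound 1 differs from compound 2 by hydrogen in place of methyl on a saturated chain carbon bound to an amide-type nitrogen in a ring, and that step gave a 2.3-fold higher number from compound 2 to compound 1 (0.35 log units; beyond the scatter). The two changes are of the same kind but not the same. The place differs: in one case the carbon bearing the methyl is bound to an amide-type nitrogen in a ring, in the other it is bound to an oxygen next to a carbonyl group. The difference between the core of compound 2 and the core of compound 3 is not broken down here.

Resting on the precedent of a 2.3-fold higher number from compound 2 to compound 1 (0.35 log units; beyond the scatter), the step from compound 3 to compound 4 is expected to be small and in the same direction, a 1.5-fold higher number from compound 3 to compound 4 (0.16 log units; within the scatter), with wide uncertainty given the different surroundings. Compound 4 is therefore estimated at 1800 nM, within a range from 800 nM to 4200 nM.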

Compound 4, half-maximal inhibitory concentration: 1900 nM
Estimate against measurement, compound 4: 1.1-fold (0.02 log units) below; the range from low to high includes it.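

Shortening ethoxycarbonyl to methoxycarbonyl in this assay gives a 1.5-fold higher number from compound 3 to compound 4 (0.19 log units; within the scatter) and so leaves the two values indistinguishable on this core. Set beside the earlier removal of a methyl group on a different core, the new step cannot be told apart from it, so the change can be said to carry over between these two cores without a detectable difference in size: the same change on two cores in this assay, a 2.3-fold higher number (0.35 log units; beyond the scatter) from compound 2 to compound 1 and a 1.5-fold higher number (0.19 log units; within the scatter) from compound 3 to compound 4, 1.5-fold (0.17 log units) apart, within the scatter of two such steps. This does not establish a rule for the series, since it rests on a single pair of compounds on each core, the earlier step lies beyond the scatter while the new one lies within it, and the methyl group leaves from a different place in each case, on a carbon bound to an amide-type nitrogen in a ring in one and on a carbon bound to an oxygen next to a carbonyl group in the other.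

The compounds shown leave open how this assay would respond if a longer chain, such as propoxycarbonyl or butoxycarbonyl, stood in place of the ethoxycarbonyl group. From the compounds shown here alone, they also leave open what a carboxylic acid or an amide at that place would give, so the reach of this ester group beyond the ethyl and methyl forms remains untested here.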